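Swapping the amide aryl group of compound 2

This account rests on a few compounds, and the source may have more. Where it says the series, first, only, none or still open, it means among the compounds named here.

Compound 2 `COc1cc2c(Nc3nc4ccc(C(=O)Nc5c(C)cccc5Cl)cc4s3)ncnc2cc1OCCCN1CCCCC1` shows the highest number among the two measured compounds in a functional assay on A549 cells (Homo sapiens) for cytotoxicity, read by WST assay, with a stated time of 72 h (on this read-out lower numbers stand for stronger inhibition and higher numbers for weaker inhibition), giving 12800 nM. Within the data shown here, its only measured neighbour, compound 1 `COc1cc2c(Nc3nc4ccc(C(=O)Nc5c(C)cc(C)cc5C)cc4s3)ncnc2cc1OCCCN1CCC(C)CC1`, gives 5400 nM in this assay, a gap that lies beyond the usual scatter; compound 1 differs from compound 2 at two places, so no single-point step connects them.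

Compound 3 `COc1cc2c(Nc3nc4ccc(C(=O)Nc5c(C)cc(C)cc5C)cc4s3)ncnc2cc1OCCCN1CCCCC1` is obtained from compound 2 by one change: 2,4,6-trimethylphenyl in place of 2-chloro-6-methylphenyl on an amide-type nitrogen. After this change, compound 3 carries the same amide aryl group as compound 1 and differs from compound 1 only in the amine at the end of the propoxy chain.

Compound 3 is therefore expected to land closer to compound 1, with an estimated step of a 2.0-fold lower number from compound 2 to compound 3 (0.29 log units; within the scatter) toward a lower number in this assay. For compound 3 the estimated value is 6500 nM, with an expected range from 2500 nM to 16000 nM.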

Compound 3, half-maximal inhibitory concentration: 10300 nM
Compound 3: the middle estimate sits 1.6-fold (0.20 log units) below what was measured, and the stated range covers the measured number.
By their numbers in this assay, from the lowest: compounds 1, 3 and 2 (each within the scatter of the next, the first and the last beyond it).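

In this assay, placing 2,4,6-trimethylphenyl instead of 2-chloro-6-methylphenyl on the amide-type nitrogen gives a 1.2-fold lower number from compound 2 to compound 3 (0.09 log units; within the scatter), so on this read-out these two aryl groups cannot be told apart. Among these compounds, the other single-point comparison, hydrogen in place of methyl on a saturated ring carbon, gives a 1.9-fold higher number from compound 1 to compound 3 (0.28 log units; within the scatter), so the gap between the first and last compounds is not carried by either single step alone, as each stays within the scatter. Nothing measured here offers a reason for either step.

As far as these compounds go, whether an amide aryl group carrying a methoxy group or a carboxylic acid would move the number remains open. So does the effect of a morpholine in place of the piperidine at the end of the propoxy chain.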